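The source may hold more compounds than are shown below. What is called first, only, known or untested is meant among the compounds shown, and "the series" means these compounds.

Measured compounds in an ADME assay on HEp-2 cells (Homo sapiens) for cytotoxicity, read by MTT assay, with a stated time of 3 days; on this read-out higher numbers stand for lower toxicity in this test and lower numbers for higher toxicity in this test: compound 1 `CCCC[C@H](CCn1cncn1)c1ccc(Cl)cc1Cl` gives 13.4 ug/mL; compound 2 `CCCC[C@@H](CCn1cncn1)c1ccc(Cl)cc1Cl` gives 6.5 ug/mL; compound 3 `c1ccc(C[C@H](CCn2cncn2)c2ccccc2)cc1` gives 60.9 ug/mL.

Among these three, compound 2 has the lowest number, which in this assay means the strongest cell toxicity seen so far. Its nearest neighbour is compound 1, the mirror-image partner: the change a 2.1-fold lower number from compound 1 to compound 2 (0.31 log units; beyond the scatter) is modest but beyond the scatter, and because the fact that compounds 1 and 2 differ only in the configuration as drawn the two share every atom and bond, only the spatial arrangement at one chain carbon differs. Among the measured compounds shown here, compound 3 stands far higher, and no single step links it to compound 2.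

Compound 4 `Clc1ccc([C@H](CCn2cncn2)Cc2ccccc2)c(Cl)c1` is not yet measured. It differs from compound 2 in one place: phenyl in place of propyl on a saturated chain carbon, two bonds along the chain from an aromatic carbon, so that the butyl chain of compound 2 becomes a benzyl group while the dichlorinated aromatic ring and the triazole are kept. For the measured compounds named here, none of the measured steps touches this kind of change; the only step in hand is the configurational one between compound 1 and compound 2. Compound 3, which also carries a benzyl group but lacks the two chlorines, gives a much higher number than compound 2, yet that comparison mixes two changes.

For compound 4 in this assay the expectation is a modest rise in the number, a 1.8-fold higher number from compound 2 to compound 4 (0.27 log units; within the scatter), with an estimate of 12 ug/mL and a range from 5 ug/mL to 30 ug/mL.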

Compound 4, half-maximal cytotoxic concentration: 4.9 ug/mL
The estimate for compound 4 lay 2.4-fold (0.39 log units) above the measured number, and the stated range ends above it.
By their numbers in this assay, from the lowest: compounds 4 and 2 (each within the scatter of the next); then compound 1; then compound 3.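

In this assay, exchanging the butyl chain for a benzyl group, which puts phenyl in place of propyl on a saturated chain carbon, two bonds along the chain from an aromatic carbon, gives a 1.3-fold lower number from compound 2 to compound 4 (0.12 log units; within the scatter), so this test cannot separate the two compounds. Among the compounds shown here, this is the first direct reading of a change at this position, and it shows that, with the rest of compound 2 kept, an added six-membered aromatic ring of carbon only gives a number within the scatter of the open chain. Nothing in hand explains why a ring and an open chain read so alike here.

The compounds shown leave open how this position responds to a group that is not built of carbon alone, such as an amine or a carboxylic acid, and how a longer chain would read there. They also leave open how the mirror image of compound 4 would compare with compound 4, as the only configurational step shown joins compound 1 to compound 2.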